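This account rests on a few compounds, and the source may have more. Where it says the series, first, only, none or still open, it means among the compounds named here.

Working notes on the series. Compound 1 `Cc1nc(N)nc2c1c(-c1ccc3oc(N)nc3c1)nn2C(C)C`, compound 2 `CC(C)n1nc(-c2ccc3oc(N)nc3c2)c2c(CO)nc(N)nc21`, compound 3 `CC(C)n1nc(-c2ccc3oc(N)nc3c2)c2c(F)nc(N)nc21` and compound 4 `CC(C)n1nc(-c2ccc3oc(N)nc3c2)c2c(C#N)nc(N)nc21` share one core and differ at a single aromatic carbon. Among the compounds with values here, in an ADME assay on cells (Hepatocyte, Homo sapiens) for metabolic stability, read by LC-MS, with a stated time of 90 min, tested at 1 uM (a lower number here means slower removal, a higher number faster removal of the compound), compound 3 gives 57 uL/min, the only number in the set. Compound 1 reaches only the assay limit, < 5 uL/min. Compound 2 likewise sits at the limit, < 5 uL/min. Both measured steps run toward compound 3, starting from the limit of < 5 uL/min in this assay, at which 2 of the 3 values shown sit: an at least 11-fold higher number from compound 1 to compound 3 (1.05 log units; beyond the scatter) and an at least 11-fold higher number from compound 2 to compound 3 (1.05 log units; beyond the scatter). The change to compound 4 is cyano in place of fluoro on an aromatic carbon. Neither measured step involves a cyano group, so they bear on this change only indirectly, showing that fluoro alone gave the high number. For compound 4 the expected step is a 2.9-fold lower number from compound 3 to compound 4 (0.45 log units; beyond the scatter), a decrease carrying wide uncertainty. Compound 4 is therefore estimated at 20 uL/min, between 5 uL/min and 60 uL/min.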

Compound 4, intrinsic clearance in a liver preparation (reported as CLH), per the amount of preparation that the assay uses: < 5 uL/min
Compound 4 was reported as a limit (the forecaster's own chance of this, stated with the estimate: 25%); at least 4.0-fold (0.60 log units) between middle value and limit.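

In this assay, cyano in place of fluoro gives an at least 11-fold lower number from compound 3 to compound 4 (1.05 log units; beyond the scatter), so a second group without a hydrogen-bond donor at this aromatic carbon does not carry the high number of compound 3. Of the four groups at this position, only fluoro now gives a value that is not a limit: the limit of < 5 uL/min in this assay, at which 3 of the 4 values shown sit. The steps from compound 1 and compound 2 to compound 4 cannot be read, since both ends are limits. On these data alone, whether chloro, methoxy or an amine at this carbon would give a high number like fluoro stays open.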